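A few compounds are considered here, and "the series" means these few. Any claim that something is new, unique, unknown or untested is made for them only; others in the source may bear on it.

Compound 1 `O=C1C[C@H](NC(=O)[C@@H]2COC[C@@H]3CCCC[C@H](NC(=O)c4nccc5ccccc45)C(=O)N32)C(O)O1`: 264 nM. Compound 2 `O=C1C[C@H](NC(=O)[C@@H]2COC[C@@H]3C/C=C\C[C@H](NC(=O)c4cccc(Cl)c4)C(=O)N32)C(O)O1`: 1550 nM.

In an assay on isolated protein for inhibition of Caspase-8 (Homo sapiens) (a higher number here means a weaker inhibitor, a lower number a stronger inhibitor), compound 2 gives the higher of the two numbers, with compound 1 standing well below it. Compound 3 `O=C1C[C@H](NC(=O)[C@@H]2COC[C@@H]3C/C=C\C[C@H](NC(=O)c4ccc5ccccc5c4)C(=O)N32)C(O)O1` differs from compound 2 in a single place: naphthalen-2-yl in place of 3-chlorophenyl on a carbonyl carbon. Among the measured compounds shown here, no measured pair shows this change on its own, and compound 1 differs from compound 3 in two places, so its value offers only a loose hint. A modest move toward a lower number is expected for compound 3, the step being a 1.9-fold lower number from compound 2 to compound 3 (0.29 log units; within the scatter). The estimate for compound 3 is 800 nM, with a range from 250 nM to 2500 nM.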

Compound 3, half-maximal inhibitory concentration: 2590 nM
Compound 3: middle estimate off by 3.2-fold (0.51 log units), on the low side; the whole stated range lies below it.
By their numbers in this assay, from the lowest: compound 1; then compounds 2 and 3 (each within the scatter of the next).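

In this assay, among the compounds shown here, the first direct reading of this change, naphthalen-2-yl in place of 3-chlorophenyl on a carbonyl carbon, is a 1.7-fold higher number from compound 2 to compound 3 (0.22 log units; within the scatter) and so shows no real shift. On this carbonyl carbon the two groups read alike: a second six-membered aromatic ring of carbon only, with the chlorine gone, brings no gain. Nothing at hand explains this result. The compounds shown leave open whether the number would move with an aminomethyl group or a carboxylic acid on the aromatic ring at this place.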